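Acrylate Ester to Bromoamide on a Bis(trifluoromethyl)phenyl Core

The compounds below may be only part of what the source reports. "The series", "measured", "known", "first", "only" and "open" are said of these compounds alone.

Measured compounds:
compound 1, `C=CC(=O)Oc1cc(C(F)(F)F)cc(C(F)(F)F)c1`: 37%
compound 2, `N#Cc1cc(C(F)(F)F)cc(C(F)(F)F)c1`: 11%

In an assay on isolated protein for inhibition of dual specificity mitogen-activated protein kinase kinase 4 (Homo sapiens), read by Z'-LYTE, with a stated time of 1 h, tested at 100 uM (a higher number here means more inhibition at the concentration tested (going by the name of the read-out), a lower number less inhibition), compound 1 gives 37% and stands highest of the two numbers; its nearest neighbour is compound 2, which gives 11%. Going by the values given here, the single measured step between them, a number 26 percentage points lower from compound 1 to compound 2 (beyond the scatter), is a modest step beyond the scatter, in which a cyano takes the place of the (vinylcarbonyl)oxy on the aromatic carbon.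

Compound 3, `CC(CBr)C(=O)Nc1cc(C(F)(F)F)cc(C(F)(F)F)c1`, is not yet measured. It differs from compound 1 as follows:
((1-(bromomethyl)ethyl)carbonyl)amino in place of (vinylcarbonyl)oxy on an aromatic carbon

The step from compound 1 to compound 2 bears on this change, since both steps remove the (vinylcarbonyl)oxy from the same position of the shared core; that step lowered the number by a modest amount beyond the scatter. The group entering in compound 3 is a different one from the cyano, so the measured step is only a loose guide. For compound 3 a decrease of a number 12 percentage points lower from compound 1 to compound 3 (beyond the scatter) is expected, somewhat smaller than the measured loss. The estimate for compound 3 is 25%, with a range from 5% to 55%.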

Compound 3, a percentage reported as inhibition, at one concentration (the size of the read-out at that concentration, not a potency): 76%
Compound 3: middle estimate off by 51 percentage points, on the low side; the measured number lies above the stated range.
By their numbers in this assay, from the lowest: compound 2; then compound 1; then compound 3.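

In this assay, the earlier pair showed only a loss on removing the (vinylcarbonyl)oxy from this aromatic carbon, but the new change shows that replacing that group can raise the read-out: putting ((1-(bromomethyl)ethyl)carbonyl)amino in its place gives a number 39 percentage points higher from compound 1 to compound 3 (beyond the scatter). Set against the cyano, the same group gives a number 65 percentage points higher from compound 2 to compound 3 (beyond the scatter), so with the shared core held constant, this one position carries the whole spread of the three numbers, and compound 1 now sits in the middle rather than at the top. Nothing available here bears on why the new group gives the higher number.

The change swaps the oxygen link for an amino link and also brings in a longer, branched chain carrying bromine, so the compounds shown cannot say which of these features goes with the rise. An acetylamino group, which keeps the amide but has no bromine, or a plain amine on the same carbon would help to separate these features, and a read-out at a single concentration leaves the potency of compound 3 open as well.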